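The source may hold more compounds than are shown below. What is called first, only, known or untested is meant among the compounds shown, and "the series" means these compounds.

In a functional assay on A549 cells (Homo sapiens) for antiproliferative activity, read by MTT assay, with a stated time of 48 h (on this read-out lower numbers stand for stronger inhibition and higher numbers for weaker inhibition), compound 2 `COc1ccc(/C=C/c2cc(OC)cc(OC)c2/C=C/C(=O)c2ccccc2C)cc1` gives 5.9 ug/mL and compound 1 `COc1ccc(/C=C/c2cc(OC)cc(OC)c2/C=C/C(=O)c2ccc(Br)cc2)cc1` gives 8.3 ug/mL on the same read-out, so the two stand within the scatter of each other. Compound 3 `COc1ccc(/C=C/c2cc(OC)cc(OC)c2/C=C/C(=O)c2ccc(C)cc2C)cc1` differs from compound 2 by methyl in place of hydrogen on an aromatic carbon in one place: methyl in place of hydrogen on an aromatic carbon, meta to a methyl group and para to a large group, turning 2-methylphenyl into 2,4-dimethylphenyl. Among the measured compounds shown here, the one measured step that bears on this is a 1.4-fold lower number from compound 1 to compound 2 (0.15 log units; within the scatter) and it lies within the scatter, so in this assay no shift beyond the scatter is expected in either direction. The estimated step is a 1.1-fold lower number from compound 2 to compound 3 (0.03 log units; within the scatter) on this reasoning. Compound 3 is expected at 5.5 ug/mL with a range from 2.8 ug/mL to 11 ug/mL in this estimate.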

Compound 3, half-maximal inhibitory concentration: 0.3 ug/mL
Compound 3: middle estimate off by 18-fold (1.26 log units), on the high side, and the stated range ends above it.
By their numbers in this assay, from the lowest: compound 3; then compounds 2 and 1 (each within the scatter of the next).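

In this assay, one added methyl on the aromatic carbon, meta to a methyl group and para to a large group, gives a 20-fold lower number from compound 2 to compound 3 (1.29 log units; beyond the scatter), so this position responds strongly to a very small change. Replacing 4-bromophenyl with 2,4-dimethylphenyl gives a 28-fold lower number from compound 1 to compound 3 (1.44 log units; beyond the scatter), whereas the earlier step between the other two compounds stayed within the scatter. No measurement here explains the stronger inhibition. Still open, going by these compounds, is whether this methyl would give the same gain without the 2-methyl group, and whether an ethyl or methoxy group in its place would keep it.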